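Pyridin-2-yl for 4-nitrophenyl on a second, smaller ring

The source may hold more compounds than are shown below. What is called first, only, known or untested is meant among the compounds shown, and "the series" means these compounds.

Compound 1 `CO[C@@H]1CC=C2NN(c3ccc([N+](=O)[O-])cc3)C(=O)CC[C@]2(c2ccccc2)O1` gives 9490 nM in a functional assay on A549 cells (Homo sapiens) for cytotoxicity, read by sulforhodamine B assay, with a stated time of 48 h; on this read-out higher numbers stand for weaker inhibition and lower numbers for stronger inhibition. Compound 2 `CO[C@@H]1CC=C2NN(c3ccccn3)C(=O)CC[C@]2(c2ccccc2)O1` gives 1480 nM. The change between them, (pyridin-2-yl in place of 4-nitrophenyl on an amide-type nitrogen in a ring), produced a 6.4-fold lower number from compound 1 to compound 2 (0.81 log units; beyond the scatter). Compound 3 `CO[C@@H]1CC=C2N(c3ccc([N+](=O)[O-])cc3)C(=O)C[C@]2(c2ccccc2)O1` gives 7150 nM; the difference between its core and the core of compound 1 is not broken down here, and the two numbers lie within the scatter of each other.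

Compound 4 `CO[C@@H]1CC=C2N(c3ccccn3)C(=O)C[C@]2(c2ccccc2)O1` has not yet been measured. It differs from compound 3 by pyridin-2-yl in place of 4-nitrophenyl on an amide-type nitrogen in a ring. Among the measured compounds shown here, this is the same kind of change as the one from compound 1 to compound 2, not the same: here the amide-type nitrogen sits in a five-membered non-aromatic ring with 1 nitrogen, two ring bonds from the ring atom that bears a fused ring and two from the one that bears the phenyl group, whereas before it sat in a seven-membered non-aromatic ring with 2 nitrogen, next to the ring nitrogen, three ring bonds from each of those atoms.

For the measured compounds named here, because the single precedent is a 6.4-fold lower number from compound 1 to compound 2 (0.81 log units; beyond the scatter) on a different ring, compound 4 is expected to show a smaller step, a 2.9-fold lower number from compound 3 to compound 4 (0.46 log units; beyond the scatter). Compound 4 is estimated at 2500 nM, between 1000 nM and 6500 nM.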

Compound 4, half-maximal inhibitory concentration: 6110 nM
Estimate against measurement, compound 4: 2.4-fold (0.39 log units) below; the range from low to high includes it.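

In this assay, pyridin-2-yl in place of 4-nitrophenyl on the five-membered non-aromatic ring with 1 nitrogen gave a 1.2-fold lower number from compound 3 to compound 4 (0.07 log units; within the scatter), so the clear step seen on the larger ring did not carry over. Set side by side, the two results show that the same change did not give the same step on these two cores: the same change on two cores in this assay, a 6.4-fold lower number (0.81 log units; beyond the scatter) from compound 1 to compound 2 and a 1.2-fold lower number (0.07 log units; within the scatter) from compound 3 to compound 4, 5.5-fold (0.74 log units) apart, beyond the scatter of two such steps This comparison rests on only two matched pairs, so it does not show which feature of the cores accounts for the gap, nor how the change would behave on any further core.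

From the compounds shown here alone, only 4-nitrophenyl and pyridin-2-yl appear on the amide-type nitrogen, so it remains open whether an unsubstituted phenyl, or a phenyl bearing an amine or a carboxylic acid, would also respond differently on the two cores. All four values also come from this assay, leaving open whether the same contrast between the cores would appear in other cell lines.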